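The source may hold more compounds than are shown below. What is called first, only, known or untested is meant among the compounds shown, and "the series" means these compounds.

In a physicochemical assay for solubility (a lower number here means a less soluble compound, a higher number a more soluble compound), compound 1 `O=C(c1cccc(Cl)c1)N1CCC(NS(=O)(=O)c2cc(S(=O)(=O)c3ccccc3)ccc2C(F)(F)F)CC1` gives 6300 nM and compound 2 `CC(C)(C)OC(=O)N1CCC[C@@H]1C(=O)N1CCC(NS(=O)(=O)c2cc(S(=O)(=O)c3ccccc3)ccc2C(F)(F)F)CC1` gives 25000 nM as the higher of the two numbers. Compound 3 `O=C([C@@H]1CCNC1)N1CCC(NS(=O)(=O)c2cc(S(=O)(=O)c3ccccc3)ccc2C(F)(F)F)CC1` differs from compound 2 in one place, with pyrrolidin-3-yl in place of 1-(tert-butoxycarbonyl)pyrrolidin-2-yl on a carbonyl carbon. For the measured compounds named here, only one measured step bears on this place, and a 4.0-fold higher number from compound 1 to compound 2 (0.60 log units; beyond the scatter) is modest but beyond the scatter. A step of similar size is expected, again toward a higher number in this assay on this slender evidence. The expected step is a 2.4-fold higher number from compound 2 to compound 3 (0.38 log units; beyond the scatter) in this reading. Compound 3 is estimated at 60000 nM with an expected range from 20000 nM to 180000 nM in all.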

Compound 3, solubility: 12500 nM
The estimate for compound 3 lay 4.8-fold (0.68 log units) above the measured number, and the stated range ends above it.
By their numbers in this assay, from the lowest: compounds 1, 3 and 2 (each within the scatter of the next, the first and the last beyond it).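

In this assay, pyrrolidin-3-yl on the carbonyl carbon gives a 2.0-fold lower number from compound 2 to compound 3 (0.30 log units; within the scatter) and also a 2.0-fold higher number from compound 1 to compound 3 (0.30 log units; within the scatter). At this position, therefore, pyrrolidin-3-yl cannot be told apart from either 1-(tert-butoxycarbonyl)pyrrolidin-2-yl or 3-chlorophenyl, even though those two groups are separated by a step beyond the scatter. No measurement shown here offers an explanation for this reading.

The change from compound 2 to compound 3 removes the tert-butoxycarbonyl group and moves the ring attachment together, so their separate contributions remain unresolved. From the compounds shown here alone, how an unsubstituted pyrrolidin-2-yl, a carboxylic acid or a longer amine chain on this carbonyl carbon would read remains open.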